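This account rests on a few compounds, and the source may have more. Where it says the series, first, only, none or still open, it means among the compounds named here.

Measured compounds:
compound 1 `CCCn1c(=O)c2nc(-c3cnn(Cc4cccc(C)c4)c3)[nH]c2n(CCC)c1=O` — 36 nM
compound 2 `CCCn1c(=O)c2nc(-c3cnn(Cc4cc(C(F)(F)F)ccc4Cl)c3)[nH]c2n(CCC)c1=O` — 22 nM
compound 3 `CCCn1c(=O)c2nc(-c3cnn(Cc4c(F)cccc4F)c3)[nH]c2n(CCC)c1=O` — 390 nM

All three share one core and differ only in the aryl group carried on the saturated chain carbon bound to an aromatic nitrogen. In an in vitro assay on HEK293 cells for displacement of a labelled ligand from adenosine receptor A2b (Homo sapiens) (a higher number here means a weaker inhibitor, a lower number a stronger inhibitor), compound 3 gives 390 nM, the highest of the three numbers and therefore the weakest binder shown: the step of an 11-fold higher number from compound 1 to compound 3 (1.03 log units; beyond the scatter) and the step of an 18-fold higher number from compound 2 to compound 3 (1.25 log units; beyond the scatter) are both well beyond the scatter, whereas the step of a 1.6-fold lower number from compound 1 to compound 2 (0.21 log units; within the scatter) is not.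

Compound 4 `CCCn1c(=O)c2nc(-c3cnn(Cc4cccc(Cl)c4)c3)[nH]c2n(CCC)c1=O` has not yet been measured in this assay. It differs from compound 3 in one place: 3-chlorophenyl in place of 2,6-difluorophenyl on a saturated chain carbon bound to an aromatic nitrogen. For the measured compounds named here, the entering group is a single-substituted ring of the same kind as the one in compound 1, which differs from it only in the identity of that one substituent, while the leaving 2,6-difluorophenyl is what set compound 3 apart. The relevant measured steps are the two large rises from compound 1 and compound 2 to compound 3; moving back from 2,6-difluorophenyl to a once-substituted ring should undo most of that rise. Compound 4 is therefore expected to show a large fall in this assay, about an 11-fold lower number from compound 3 to compound 4 (1.05 log units; beyond the scatter), and the expected value for compound 4 is 35 nM, with a range of 15 nM to 80 nM.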

Compound 4, inhibition constant: 18 nM
Beside the measured number, compound 4's estimate is 1.9-fold (0.29 log units) above it, and the stated range covers the measured number.
By their numbers in this assay, from the lowest: compounds 4, 2 and 1 (each within the scatter of the next); then compound 3.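

Moving from 2,6-difluorophenyl to 3-chlorophenyl gives a large step in this assay (a 22-fold lower number from compound 3 to compound 4 (1.34 log units; beyond the scatter)), which shows that the weak binding of compound 3 is not shared by a second ring with a single substituent. Chloro in place of methyl on an aromatic carbon stays within the scatter (a 2.0-fold lower number from compound 1 to compound 4 (0.30 log units; within the scatter)), as does the exchange of the more heavily substituted ring for 3-chlorophenyl (a 1.2-fold lower number from compound 2 to compound 4 (0.09 log units; within the scatter)), so the different rings of compound 1, compound 2 and compound 4 give similar numbers and only compound 3 goes against that pattern. No supporting measurement bears on the reason for the gap between compound 3 and the other three.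

The shown rings do not separate the effect of having fluorine on the ring from that of where the substituents sit, and a ring carrying a single fluorine would help to tell these apart. From the compounds shown here alone, it also remains open how binding responds to an unsubstituted phenyl, or to a ring carrying an amine or a carboxylic acid.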